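A few compounds are considered here, and "the series" means these few. Any claim that something is new, unique, unknown or untested is made for them only; others in the source may bear on it.

Measured in a physicochemical assay for lipophilicity, at pH 7.4; on this read-out higher numbers stand for higher lipophilicity and lower numbers for lower lipophilicity:
- Compound 1 `CCOCc1cccc2c1CCC2c1ncc[nH]1`: 2.1
- Compound 2 `Cc1noc(Cc2cccc3c2CC[C@H]3c2ncc[nH]2)n1`: 2

Going by the values given here, these are the only two measurements so far, and they lie within the usual scatter of each other. Compound 1 therefore cannot be told apart from compound 2 on this scale.

Compound 3 `Fc1ccn(Cc2cccc3c2CCC3c2ncc[nH]2)n1` has not yet been measured. Its difference from compound 1 is 3-fluoro-1H-pyrazol-1-yl in place of ethoxy on a saturated chain carbon bound to an aromatic carbon. In words, 3-fluoro-1H-pyrazol-1-yl stands in place of ethoxy on a saturated chain carbon bound to an aromatic carbon. The same difference can also be read as ethoxymethyl to (3-fluoro-1H-pyrazol-1-yl)methyl.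

Among the compounds with values here, no two measured compounds differ in just one place, so no measured step can serve as a guide. Within the data shown here, the only anchor is that compound 1 at 2.1 and compound 2 at 2 sit close together, which keeps the expectation near them. In this assay a small upward step is expected, a number 0.20 log units higher from compound 1 to compound 3 (within the scatter), which would stay within the usual scatter. The direction is a tentative judgment. For compound 3 the estimated value is 2.3, with an expected range of 1.8 to 2.8.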

Compound 3, distribution coefficient: 2.4
Estimate against measurement, compound 3: 0.10 log units below, within the range that was stated.
By their numbers in this assay, from the lowest: compounds 2, 1 and 3 (each within the scatter of the next, the first and the last beyond it).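

Going by these compounds alone, this is the first step measured at this position: in this assay, putting 3-fluoro-1H-pyrazol-1-yl in place of ethoxy on a saturated chain carbon bound to an aromatic carbon gives a number 0.30 log units higher from compound 1 to compound 3 (within the scatter). The swap is a substantial one on paper, with an open group of 3 heavy atoms and no ring giving way to a group of 6 heavy atoms with one five-membered aromatic ring, yet the two compounds cannot be told apart on this scale. Nothing measured here speaks to why the read-out stays so close across so different a pair of groups.

On these data alone, a single step within the scatter sets no trend for this position, so it remains open whether a plain 1H-pyrazol-1-yl without the fluorine would read the same as compound 3. As far as these compounds go, it also remains open whether an amine or a carboxylic acid at the same place would move the number clear of the scatter, which would show how much room this read-out has to respond to a change here.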